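A few compounds are considered here, and "the series" means these few. Any claim that something is new, unique, unknown or untested is made for them only; others in the source may bear on it.

In a physicochemical assay for solubility, in phosphate buffer, measured as kinetic solubility (a higher number here means a more soluble compound, a lower number a less soluble compound), the measured compounds stand as follows:
- compound 1 `CC(C)C(c1ccc(-c2ccc3cccc(F)c3c2)[nH]c1=O)N1CCCCC1=O` gives 23100 nM
- compound 2 `CC(C)C(c1nnc[nH]1)c1ccc(-c2ccc3cccc(F)c3c2)[nH]c1=O` gives 24500 nM
- compound 3 `CC(C)C(CC(N)=O)c1ccc(-c2ccc3cccc(F)c3c2)[nH]c1=O` gives 5600 nM

Compound 3 holds the lowest number of the three, and its gaps to both others lie beyond the scatter. Compound 4 `Cc1c[nH]c(C(c2ccc(-c3ccc4cccc(F)c4c3)[nH]c2=O)C(C)C)n1` has not yet been measured. The change 4-methyl-1H-imidazol-2-yl in place of carbamoylmethyl on a saturated chain carbon bound to an aromatic carbon and a saturated chain carbon puts 4-methyl-1H-imidazol-2-yl in place of carbamoylmethyl on a saturated chain carbon bound to an aromatic carbon and a saturated chain carbon.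

All three measured steps concern this same carbon. The nearest guide is a 4.4-fold lower number from compound 2 to compound 3 (0.64 log units; beyond the scatter) and it is modest. The step of a 4.1-fold lower number from compound 1 to compound 3 (0.62 log units; beyond the scatter) is also modest and of similar size. The third step of a 1.1-fold higher number from compound 1 to compound 2 (0.03 log units; within the scatter) shows that two quite different groups can give matching values. Compound 2 has the measured group closest to the entering one, so a modest rise is expected on leaving carbamoylmethyl. Among the compounds with values here, no measured compound carries the 4-methyl-1H-imidazol-2-yl group, so the rise may not fully reach the level of compound 2. The expected move is a 2.7-fold higher number from compound 3 to compound 4 (0.43 log units; beyond the scatter) and it is a rise. For compound 4 the estimated value is 15000 nM with an expected range from 6000 nM to 35000 nM in this assay.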

Compound 4, solubility: 15200 nM
Compound 4: the middle estimate sits 1.0-fold (0.01 log units) below what was measured; low and high end bracket the measured number.
By their numbers in this assay, from the lowest: compound 3; then compounds 4, 1 and 2 (each within the scatter of the next).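

In this assay, the step of a 2.7-fold higher number from compound 3 to compound 4 (0.43 log units; beyond the scatter) shows that a second aromatic group on the saturated chain carbon stands apart from carbamoylmethyl, so the gap is not confined to the pair of compound 2 and compound 3. Within the data shown here, the steps of a 1.6-fold lower number from compound 2 to compound 4 (0.21 log units; within the scatter) and a 1.5-fold lower number from compound 1 to compound 4 (0.18 log units; within the scatter) both lie within the scatter, which leaves 4-methyl-1H-imidazol-2-yl, 4H-1,2,4-triazol-3-yl and 2-oxopiperidin-1-yl indistinguishable here, with carbamoylmethyl in compound 3 the only one of the four groups set apart. The leaving and entering groups have the same hydrogen-bond donor and acceptor counts and no net charge, so these counts do not separate compound 3 from compound 4, and no measurement is available to explain the gap.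

Among these compounds, compound 3 is the only compound here whose group has no ring, so one open-chain example cannot show whether the absence of a ring goes with its lower number. Going by these compounds, whether an amine, a carboxylic acid or a longer chain ending in an amide on this carbon would fall with compound 3 or with the other three remains open.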